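From 2-Fluorophenyl to 4-Cyanophenyl: An Expected Small Step

A few compounds are considered here, and "the series" means these few. Any claim that something is new, unique, unknown or untested is made for them only; others in the source may bear on it.

In a functional assay on HeLa cells (Homo sapiens) for cytotoxicity, read by MTT assay, with a stated time of 24 h (a lower number here means a stronger inhibitor, a higher number a weaker inhibitor), compound 1 `COc1cc(/C=C2\CN(C)C/C(=C\c3ccccc3F)C2=O)cc(OC)c1` gives 5450 nM, and compound 2 `COc1cc(/C=C2\CN(C)C/C(=C\c3ccccc3F)C2=O)cc(OC)c1OC` gives 3220 nM. Among the compounds with values here, these are the only two numbers so far, and they lie within the scatter of each other, so compound 1 holds no distinct rank. Compound 3 `COc1cc(/C=C2\CN(C)C/C(=C\c3ccc(C#N)cc3)C2=O)cc(OC)c1` keeps the core of compound 1 and carries one change: 4-cyanophenyl in place of 2-fluorophenyl on a double-bonded chain carbon bound to a double-bonded ring carbon. Within the data shown here, the only measured step, a 1.7-fold lower number from compound 1 to compound 2 (0.23 log units; within the scatter), is methoxy in place of hydrogen on an aromatic carbon and leaves the 2-fluorophenyl in place, so no measured step speaks directly to this swap. Nothing beyond the scatter is therefore expected in this assay, and the expected change is a 1.4-fold lower number from compound 1 to compound 3 (0.13 log units; within the scatter). For compound 3 the estimate is 4000 nM, with an estimated range of 1500 nM to 11000 nM.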

Compound 3, half-maximal inhibitory concentration: 3420 nM
The estimate for compound 3 lay 1.2-fold (0.07 log units) above the measured number; the range from low to high includes it.
By their numbers in this assay, from the lowest: compounds 2, 3 and 1 (each within the scatter of the next).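

Within the data shown here, this is the first look at the place on a double-bonded chain carbon bound to a double-bonded ring carbon, which the earlier step left untouched: in this assay, the swap to 4-cyanophenyl gives a 1.6-fold lower number from compound 1 to compound 3 (0.20 log units; within the scatter). This place therefore takes a group with a triple bond and a hydrogen-bond acceptor, neither of which 2-fluorophenyl has, without a shift beyond the scatter. Nothing available gives a reason for this result.

The compounds shown leave open whether a group of another kind at this place, such as a carboxylic acid, an amine or a longer chain, would move the number beyond the scatter. They also leave open whether 4-cyanophenyl would give a similar result on the core of compound 2.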